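The compounds below may be only part of what the source reports. "The series", "measured", "known", "first", "only" and "open" are said of these compounds alone.

Two compounds share one core and differ only in the group on a carbonyl carbon. Compound 1 `O=C(NC[C@@H]1C[C@@H]2C=C[C@@H]1C2)NS(=O)(=O)N1CCC(CCNC(=O)c2cscn2)CC1` carries a 1,3-thiazol-4-yl there; in a functional assay on the whole organism (blood) with Rattus norvegicus as the target, with stated times of 24 h and 1 h, at a dose of 15 mg/kg by the intraperitoneal route (on this read-out lower numbers stand for a weaker effect and higher numbers for a stronger effect at the one dose given), compound 1 gives 37%. Compound 2 `O=C(NC[C@@H]1C[C@@H]2C=C[C@@H]1C2)NS(=O)(=O)N1CCC(CCNC(=O)c2nc3ccccc3s2)CC1` carries a 1,3-benzothiazol-2-yl instead; in this assay compound 2 gives 34%. The step of a number 3 percentage points lower from compound 1 to compound 2 (within the scatter) shows that this exchange on the carbonyl carbon left the read-out essentially unchanged, and compound 2 thus stands within the scatter of compound 1, with nothing separating the two beyond repeat variation.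

Compound 3 `O=C(NC[C@@H]1C[C@@H]2C=C[C@@H]1C2)NS(=O)(=O)N1CCC(CCNC(=O)c2cccc3c2OCCO3)CC1` is not yet measured. It differs from compound 2 in the same place: 2,3-dihydro-1,4-benzodioxin-5-yl in place of 1,3-benzothiazol-2-yl on a carbonyl carbon. Going by the values given here, the only step that bears on this change is the one from compound 1 to compound 2, where a different group on the same carbonyl carbon gave a difference within the scatter. On that basis no step beyond the scatter is expected in this assay for compound 3, in either direction, and the estimated step of a number 1 percentage points higher from compound 2 to compound 3 (within the scatter) is small. Compound 3 is therefore expected to give about 35%, with a range from 18% to 52%.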

Compound 3, a percentage reported as activity, at one dose (the size of the read-out at that dose, not a potency): 40%
For compound 3 the middle estimate is 5 percentage points below the measured one, within the range that was stated.
By their numbers in this assay, from the lowest: compounds 2, 1 and 3 (each within the scatter of the next).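

With the 2,3-dihydro-1,4-benzodioxin-5-yl group, the carbonyl carbon now carries a group without nitrogen or sulfur, its two oxygens sitting in a six-membered non-aromatic ring, and this assay still shows a number 6 percentage points higher from compound 2 to compound 3 (within the scatter) and a number 3 percentage points higher from compound 1 to compound 3 (within the scatter). The earlier pair had only shown that two aromatic groups containing nitrogen and sulfur could not be told apart, whereas these three compounds show that the read-out also fails to separate them from a group of a different ring type and hetero atom content, so all three groups on this carbonyl carbon lie within the scatter of one another. Nothing available explains why these three groups read alike.

On these data alone, all three groups contain an aromatic ring attached directly to the carbonyl carbon, so it remains open whether a group of another kind there, such as a carboxylic acid, an amine or a longer alkyl chain, would give a step beyond the scatter. As far as these compounds go, because the read-out comes from a single dose, it also remains open whether these three compounds would stay this close at other doses.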